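The compounds below may be only part of what the source reports. "The series", "measured", "known", "first", "only" and "open" are said of these compounds alone.

Two amidine thiosemicarbazides have been run in a functional assay on A-431 cells (Homo sapiens) for cytotoxicity, read by MTT assay, with a stated time of 72 h, tested at 1 uM; on this read-out higher numbers stand for more inhibition of growth at the one concentration tested and lower numbers for less inhibition of growth. Among the measured compounds shown here, compound 1 `N/C(=N\NC(=S)N1CCOCC1)c1ccccn1` gives 29.2%; compound 2 `Cc1cccc(/C(N)=N/NC(=S)N2CCSCC2)n1` gives 42.8% and so stands highest of the two numbers, with compound 1 beyond the scatter below it, though the two compounds differ in more than one place and no single step between them is counted. Compound 3 `Cc1cccc(/C(N)=N/NC(=S)N2CCOCC2)n1` is the next member to be measured. It carries morpholin-4-yl in place of thiomorpholin-4-yl on a thiocarbonyl carbon. On the numbers shown, with compound 1 also bearing morpholin-4-yl and giving 29.2%, the step of a number 9.8 percentage points lower from compound 2 to compound 3 (within the scatter) is expected to be a modest drop, possibly within the scatter. Compound 3 is estimated at 33%, between 18% and 48%.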

Compound 3, percent growth inhibition at one concentration: 47.2%
Compound 3: middle estimate off by 14.2 percentage points, on the low side; the range from low to high includes it.
By their numbers in this assay, from the lowest: compound 1; then compounds 2 and 3 (each within the scatter of the next).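

With morpholin-4-yl in place of thiomorpholin-4-yl on a thiocarbonyl carbon, this assay gives a number 4.4 percentage points higher from compound 2 to compound 3 (within the scatter), so the two rings cannot be told apart at this position. Methyl in place of hydrogen on an aromatic carbon, with morpholin-4-yl held constant, gives a number 18 percentage points higher from compound 1 to compound 3 (beyond the scatter) and is the only single change here beyond the scatter. No evidence on the cause of either step is available.

Going by these compounds, whether the methyl step holds with thiomorpholin-4-yl remains open. So does the outcome with a piperazin-1-yl ring or an open-chain dimethylamino group on the thiocarbonyl carbon.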